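This account rests on a few compounds, and the source may have more. Where it says the series, first, only, none or still open, it means among the compounds named here.

- Compound 1 `CCOC(=O)C(=O)Nc1nc(-c2ccc(Sc3ccccc3)cc2)cs1`: > 3 mg/kg (a limit, not a number)
- Compound 2 `CCOC(=O)C(=O)Nc1nc(-c2ccc(N(C)C)cc2)cs1`: about 1 mg/kg

Going by the values given here, in a functional assay on the whole organism with Rattus norvegicus as the target (on this read-out lower numbers stand for an effect already at smaller amounts and higher numbers for an effect only at larger amounts of compound), compound 2 gives about 1 mg/kg, the only actual number so far. For compound 1 there is only a limit, (the limit of > 3 mg/kg in this assay, at which 1 of the 2 values shown sits).

The next structure, compound 3 `CCOC(=O)C(=O)Nc1nc(-c2ccc(NC(=O)C(F)(F)F)cc2)cs1`, keeps the shared core and changes one group: ((trifluoromethyl)carbonyl)amino in place of dimethylamino on an aromatic carbon. Just one measured step bears on this change, and it concerns the same aromatic carbon: an at least 3.0-fold lower number from compound 1 to compound 2 (0.47 log units; beyond the scatter). That step shows that the group placed here can shift the dose beyond the scatter in this assay. However, it involves phenylsulfanyl and not ((trifluoromethyl)carbonyl)amino, so it is only a weak guide. Among the compounds with values here, the one other group measured here, on compound 1, gave a higher number than dimethylamino in the step of an at least 3.0-fold lower number from compound 1 to compound 2 (0.47 log units; beyond the scatter), so replacing dimethylamino is tentatively expected to raise the number. The expected change is a 1.5-fold higher number from compound 2 to compound 3 (0.18 log units; within the scatter), a small rise that may not leave the scatter. For compound 3 the estimate is 1.5 mg/kg, with an expected range from 0.4 mg/kg to 5 mg/kg.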

Compound 3, dose for half-maximal effect: about 1 mg/kg
Estimate against measurement, compound 3: 1.5-fold (0.18 log units) above; the measured number falls inside the stated range.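

In this assay, putting ((trifluoromethyl)carbonyl)amino on this aromatic carbon in place of dimethylamino gives no change at the digits printed from compound 2 to compound 3 (within the scatter), so a larger group that also brings a hydrogen-bond donor is accepted here without a visible shift in dose. Against phenylsulfanyl, the same group gives an at least 3.0-fold lower number from compound 1 to compound 3 (0.47 log units; beyond the scatter), which means that two quite different groups now stand on the same side of that gap, and phenylsulfanyl alone stands apart among the three groups shown. Compound 1 carries a limit and not a number, so the size of this gap is only a bound: the limit of > 3 mg/kg in this assay, at which 1 of the 3 values shown sits.

The compounds shown leave open how far this acceptance reaches, for example to a small methoxy group, a primary amine or a carboxylic acid on the same carbon. They also leave open whether the sulfur or the added phenyl ring sets phenylsulfanyl apart, a question that a phenoxy or a benzyl group in its place could help to separate.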